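Chloro for fluoro on the pendant aryl ring

This account rests on a few compounds, and the source may have more. Where it says the series, first, only, none or still open, it means among the compounds named here.

Compound 1 `CCn1cc(-c2cccc(F)c2)c(=O)c2cc(F)c(N3CCNCC3)cc21` and compound 2 `CCn1cc(-c2cccc(Cl)c2)c(=O)c2cc(F)c(N3CCNCC3)cc21` share one core; compound 3 `O=c1c(-c2ccc(F)cc2)cn(C2CC2)c2cc(N3CCNCC3)c(F)cc12` and compound 4 `O=c1c(-c2ccc(Cl)cc2)cn(C2CC2)c2cc(N3CCNCC3)c(F)cc12` share another, and the difference between the two cores is not broken down here. In a functional assay on A549 cells (Homo sapiens) for antiproliferative activity, read by MTT assay, with a stated time of 48 h (on this read-out higher numbers stand for weaker inhibition and lower numbers for stronger inhibition), compound 1 gives 3060 nM, compound 2 gives 780 nM and compound 3 gives 1680 nM. Compound 4 has not yet been measured in this assay.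

The change from compound 1 to compound 2 is chloro in place of fluoro on an aromatic carbon and it made a step of a 3.9-fold lower number from compound 1 to compound 2 (0.59 log units; beyond the scatter). The change from compound 3 to compound 4 is chloro in place of fluoro on an aromatic carbon. The two are the same kind of change, not the same: in the first pair the halogen sits meta to a large group, in the second para to a large group. Compound 3 and compound 1 lie within the usual scatter of each other, while compound 2 reads lower than compound 3 and beyond the scatter.

Resting on the single precedent a 3.9-fold lower number from compound 1 to compound 2 (0.59 log units; beyond the scatter), a step of roughly comparable size is expected from compound 3 to compound 4, a 2.8-fold lower number from compound 3 to compound 4 (0.45 log units; beyond the scatter), with the different place around the halogen widening the uncertainty. Compound 4 is therefore estimated at 600 nM in this assay, with a range from 250 nM to 1500 nM.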

Compound 4, half-maximal inhibitory concentration: 650 nM
The estimate for compound 4 lay 1.1-fold (0.03 log units) below the measured number; the measured number falls inside the stated range.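

In this assay, chloro in place of fluoro gives a 2.6-fold lower number from compound 3 to compound 4 (0.41 log units; beyond the scatter), so the number falls in the same direction on the core of compound 3 as on the core of compound 1, and the two steps cannot be told apart in size: the same change on two cores in this assay, a 3.9-fold lower number (0.59 log units; beyond the scatter) from compound 1 to compound 2 and a 2.6-fold lower number (0.41 log units; beyond the scatter) from compound 3 to compound 4, 1.5-fold (0.18 log units) apart, within the scatter of two such steps. Among the compounds shown here, this supports carrying the change between these two cores in this assay, but it rests on only two matched pairs. The pairs differ in both core and halogen place, so the separate contributions of those two differences cannot be read, and the data give no reason for the lower numbers and no rule for other cores.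

Still open, going by these compounds, is how the same swap reads when the halogen place is held fixed on one core, which would separate place from core. Also open, on these data alone, is whether bromo or methoxy at the position of the halogen would extend the step or break it.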